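Swapping a hydroxy for a propylsulfonylamino group

A few compounds are considered here, and "the series" means these few. Any claim that something is new, unique, unknown or untested is made for them only; others in the source may bear on it.

Of the compounds shown here, three have been measured in an assay on isolated protein for binding affinity to Alpha-1D adrenergic receptor (Rattus norvegicus), read by radioligand binding; a higher number here means a weaker inhibitor, a lower number a stronger inhibitor. Compound 1, `Oc1cccc2c1CCCC2c1c[nH]cn1`, gives 30.9 nM, the lowest of the three numbers. Compound 2, `CS(=O)(=O)Nc1ccc(Cl)c2c1CCCC2c1c[nH]cn1`, gives 2880 nM, and compound 3, `CCS(=O)(=O)Nc1cc(C2CCCCC2)cc2c1CCCC2c1c[nH]cn1`, gives 447 nM. Both of these carry a sulfonylamino group where compound 1 carries a hydroxy, but each also carries a further group on the core, so neither pair with compound 1 shows a single change, and their values can only be read as a loose hint that sulfonamide-bearing members of this series have sat well above compound 1.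

Compound 4, `CCCS(=O)(=O)Nc1cccc2c1CCCC2c1c[nH]cn1`, is the unmeasured case: (propylsulfonyl)amino in place of hydroxy on an aromatic carbon. Nothing else on the shared core changes. Given that compounds 2 and 3 sit far above compound 1, a loss of affinity is the expected direction, and a step of a 9.7-fold higher number from compound 1 to compound 4 (0.99 log units; beyond the scatter) is estimated. Compound 4 is therefore expected to give about 300 nM in this assay, with a plausible range from 60 nM to 1500 nM.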

Compound 4, inhibition constant: < 10000 nM
Compound 4: no number, only a limit; the forecaster's own chance of this, stated with the estimate: 3%; the middle value does not contradict the limit.
By their numbers in this assay, from the lowest: compound 1; then compound 3; then compound 2.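

Within the data shown here, compound 4 gives < 10000 nM, which is a limit of the assay and not a number, so no step from compound 1 to compound 4 can be read. The compounds shown leave open how far (propylsulfonyl)amino in place of hydroxy shifts the value.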